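The source may report more compounds than this note shows. Statements on the series, on what has been measured and on what is new or still open speak of the compounds shown alone.

In an ADME assay on KB cells (Homo sapiens) for cytotoxicity (on this read-out higher numbers stand for an effect only at larger amounts of compound and lower numbers for an effect already at smaller amounts), compound 1 `COc1cc2c(c(OCc3ccccc3)c1OC)C(=O)[C@]1(OC)C=C[C@H]2N(C(=O)OCC(C)C)N1C(=O)OCC(C)C` gives 94 ug/mL, while compound 2 `COc1cc2c(c(OCc3ccc(Cl)cc3)c1OC)C(=O)[C@]1(OC)C=C[C@H]2N(C(=O)OCC(C)C)N1C(=O)OCC(C)C` gives 42 ug/mL, the lower of the two numbers. Compound 3 `COc1cc2c(c(O)c1OC)C(=O)[C@]1(OC)C=C[C@H]2N(C(=O)OCC(C)C)N1C(=O)OCC(C)C` has not yet been measured. It differs from compound 2 as follows: hydrogen in place of 4-chlorobenzyl on an oxygen on an aromatic ring. In plain terms, (4-chlorobenzyl)oxy becomes hydroxy. Going by a 2.2-fold lower number from compound 1 to compound 2 (0.35 log units; beyond the scatter), a modest step that came with chloro in place of hydrogen on an aromatic carbon, a modest move to a higher number is expected in this assay once that chloro has gone. That step covers only the chloro, however. Going by the values given here, no measured compound shows what happens when the whole 4-chlorobenzyl leaves, so the expectation remains uncertain. The expected change is a 2.1-fold higher number from compound 2 to compound 3 (0.33 log units; beyond the scatter). For compound 3 the estimated value is 90 ug/mL, with an expected range from 25 ug/mL to 300 ug/mL.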

Compound 3, concentration for half-maximal effect: > 300 ug/mL
Compound 3 was reported as a limit; the forecaster's own chance of this, stated with the estimate: 10%; at least 3.3-fold (0.52 log units) between middle value and limit.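

Going by these compounds alone, at this oxygen on an aromatic ring, the earlier compounds showed only a change on the benzyl group, whereas replacing the whole 4-chlorobenzyl with hydrogen in this assay gives an at least 7.1-fold higher number from compound 2 to compound 3 (0.85 log units; beyond the scatter). Replacing the plain benzyl with hydrogen points the same way, with an at least 3.1-fold higher number from compound 1 to compound 3 (0.50 log units; beyond the scatter), so with either group gone, an effect appears only at clearly larger amounts of compound. The reading for compound 3, > 300 ug/mL, is a limit and not a number: the limit of > 300 ug/mL in this assay, at which 1 of the 3 values shown sits.

The compounds shown leave open whether this oxygen needs the aromatic ring of the benzyl group or merely any carbon group, which a methyl or ethyl there would help to separate. They also leave open whether an amine on the benzyl ring would shift the number as chloro does.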